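The compounds below may be only part of what the source reports. "The series", "measured", "known", "first", "only" and "open" are said of these compounds alone.

Within the data shown here, compound 1 `COc1ccc2nccc(C3CN(C4CCN(Cc5cc6ccccc6[nH]5)CC4)C(=O)O3)c2c1` is the only member of this set with a numerical result: in an in vitro functional assay on RBL cells for antagonist activity at C-C chemokine receptor type 8 (Homo sapiens), read by FLIPR and calcium flux (a higher number here means a weaker inhibitor, a lower number a stronger inhibitor), compound 1 gives 25.1 nM. Compound 2 `COc1ccc2nccc(C3CN(CC4CCCN(Cc5cc6ccccc6[nH]5)C4)C(=O)O3)c2c1` returns only a limit of the assay, < 50200 nM. Compound 3 `O=C1OC(c2cnc3ccccc3c2)CN1C1CCN(Cc2cc3ccccc3[nH]2)CC1` likewise returns a limit, < 50200 nM. Two of the three results thus sit at the limit of < 50200 nM in this assay, at which 2 of the 3 values shown sit, leaving compound 1 as the sole anchor for the series. Compound 4 `COc1ccc2nccc(C3CN(C4CCN(Cc5ccccc5Cl)CC4)C(=O)O3)c2c1` keeps the core of compound 1 and alters the group on the saturated chain carbon bound to the amine nitrogen in a ring: 2-chlorophenyl in place of 1H-indol-2-yl on a saturated chain carbon bound to an amine nitrogen in a ring. Among the measured compounds shown here, no measured pair differs at this position, so the size of the step rests on expectation alone. A modest loss beyond the scatter is expected, a 4.0-fold higher number from compound 1 to compound 4 (0.60 log units; beyond the scatter). Compound 4 is estimated at 100 nM, plausibly between 20 nM and 800 nM.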

Compound 4, half-maximal inhibitory concentration: < 50200 nM
Compound 4: only a limit was reported; the forecaster's own chance of this, stated with the estimate: 10%; the middle value is on the limit's open side.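

Among these compounds, compound 4 returns only a limit (< 50200 nM), so no step from compound 1 to compound 4 can be read: the limit of < 50200 nM in this assay, at which 3 of the 4 values shown sit. Going by these compounds, the size of the difference between 1H-indol-2-yl and 2-chlorophenyl at this place remains open.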